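Amine branching shift in a triazolopyrimidine CRF1 series

The compounds below may be only part of what the source reports. "The series", "measured", "known", "first", "only" and "open" are said of these compounds alone.

Measured so far:
compound 1 `CCC(CC)Nc1nc(C)nc2c(-c3ccc(OC)nc3C)c(C)nn12` — 3.1 nM
compound 2 `CCC(CC)Nc1nc(C)nc2c(-c3c(C)cc(N(C)C)nc3C)c(C)nn12` — 25.6 nM
compound 3 `CCC(CC)Nc1nc(C)nc2c(-c3cnc(N(C)C)cc3C)c(C)nn12` — 24.8 nM

In an assay on cell membranes for displacement of a labelled ligand from corticotropin-releasing factor receptor 1 (Rattus norvegicus) (a lower number here means a stronger inhibitor, a higher number a weaker inhibitor), compound 1 gives the lowest number of the three; compound 3 is the nearest and compound 2 slightly further, both gaps beyond the scatter. Going by the values given here, the only single-point step on record, a 1.0-fold lower number from compound 2 to compound 3 (0.01 log units; within the scatter), concerns the aryl ring and is within the scatter.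

Compound 4 `CCCCC(C)Nc1nc(C)nc2c(-c3ccc(OC)nc3C)c(C)nn12` keeps the whole of compound 1 except for the amine substituent: 1-methylpentyl in place of pentan-3-yl on a nitrogen on an aromatic ring. Among the compounds with values here, no measured pair varies this side chain, so the step has no direct precedent; the two aryl-ring compounds 2 and 3 say nothing about it. The change keeps the branch point at the nitrogen-bearing carbon while lengthening one arm and shortening the other, and is treated as a modest perturbation. The expected change is a 1.9-fold higher number from compound 1 to compound 4 (0.29 log units; within the scatter), a small loss that may not clear the scatter. Compound 4 is estimated at 6 nM, with a range of 2 nM to 20 nM.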

Compound 4, half-maximal inhibitory concentration: 5.1 nM
For compound 4 the middle estimate is 1.2-fold (0.07 log units) above the measured one; the range from low to high includes it.
By their numbers in this assay, from the lowest: compounds 1 and 4 (each within the scatter of the next); then compounds 3 and 2 (each within the scatter of the next).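

In this assay, going by these compounds alone, the amine side chain is varied for the first time, and the result is a 1.6-fold higher number from compound 1 to compound 4 (0.22 log units; within the scatter) so pentan-3-yl and 1-methylpentyl cannot be told apart on the core of compound 1. On this aryl ring, the position accepts the added carbon and the unequal arms of the branch without a shift beyond the scatter. No measurement offered here explains why the two side chains read alike.

Only these two branched alkyl groups are shown at this nitrogen, so it remains open whether a cyclopropylmethyl group, a longer straight chain or a chain carrying an ether oxygen would hold the number. Also open, going by these compounds, is whether 1-methylpentyl would behave the same way on the dimethylamino-bearing aryl rings of compound 2 and compound 3.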